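Morpholin-4-yl for pyrrolidin-1-yl: estimating a cytotoxicity step

The source may hold more compounds than are shown below. What is called first, only, known or untested is meant among the compounds shown, and "the series" means these compounds.

Compound 1 `O=C(NCc1ccncc1)C1CCN(C(=O)c2cc3ccccc3n2Cc2ccc(Cl)cc2)CC1`: > 100000 nM, a limit
Compound 2 `Cn1cnc(CNC(=O)C2CCN(C(=O)c3cc4ccccc4n3Cc3ccc(Cl)cc3)CC2)c1`: > 50000 nM, a limit
Compound 3 `O=C(c1cc2ccccc2n1Cc1ccc(Cl)cc1)N1CCC(C(=O)N2CCCC2)CC1`: 65600 nM

These results come from an ADME assay on BE(2)-C cells (Homo sapiens) for cytotoxicity, read by MTT assay, with a stated time of 20 h; on this read-out higher numbers stand for lower toxicity in this test and lower numbers for higher toxicity in this test. Going by the values given here, compound 3, at 65600 nM, has the only true number here. The other two results are limits. Compound 4 `O=C(c1cc2ccccc2n1Cc1ccc(Cl)cc1)N1CCC(C(=O)N2CCOCC2)CC1` has morpholin-4-yl in place of pyrrolidin-1-yl on a carbonyl carbon. Two measured steps change the group on that carbonyl carbon. One is an at least 1.5-fold lower number from compound 1 to compound 3 (0.18 log units; that floor lies within the scatter). The other is a step that the limit leaves unreadable from compound 2 to compound 3. Neither shows a change beyond the scatter, so no step beyond the scatter is expected in this assay. The expected step is a 1.2-fold higher number from compound 3 to compound 4 (0.09 log units; within the scatter). For compound 4 the estimated value is 80000 nM, with an expected range of 40000 nM to 160000 nM.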

Compound 4, half-maximal cytotoxic concentration: > 100000 nM
Compound 4: no number, only a limit; the forecaster's own chance of this, stated with the estimate: 45%; at least 1.2-fold (0.09 log units) between middle value and limit.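

Morpholin-4-yl in place of pyrrolidin-1-yl on this carbonyl carbon gives, in this assay, an at least 1.5-fold higher number from compound 3 to compound 4 (0.18 log units; that floor lies within the scatter). Unlike the earlier steps at this carbon, this one swaps one ring directly for another, and the part of it that can be read stays within the scatter. Its full size remains unknown because compound 4 gives a limit: the limit of > 100000 nM in this assay, at which 2 of the 4 values shown sit.

The steps to compound 4 from compound 1 and compound 2 cannot be read. As far as these compounds go, whether a piperidin-1-yl or a dimethylamino group on the same carbonyl carbon would give a true number in this assay remains open.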